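Adding a Methyl to the Aromatic Ring of Compound 2

This account rests on a few compounds, and the source may have more. Where it says the series, first, only, none or still open, it means among the compounds named here.

The measured compounds and their numbers in a functional assay on SAOS-2 cells (Homo sapiens) for inhibition, read by CCK-8 assay, with a stated time of 72 h, tested at 20 uM; a lower number here means less inhibition of growth, a higher number more inhibition of growth at the concentration tested:
compound 1, `CCOC(=O)/C=C1/C(=O)Nc2ccccc21`, gives 81.4%
compound 2, `CC(C)(C)OC(=O)/C=C1/C(=O)Nc2ccccc21`, gives 83.3%
compound 3, `CC(C)(C)OC(=O)/C=C1/C(=O)N(Cc2ccccc2)c2ccccc21`, gives 82.1%

Compound 2 carries the highest of the three numbers, but neither neighbour is separated from it by more than the scatter: the step of a number 1.9 percentage points higher from compound 1 to compound 2 (within the scatter) and the step of a number 1.2 percentage points lower from compound 2 to compound 3 (within the scatter) are both within it, so the three compounds cannot be ranked on these data.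

Compound 4, `Cc1ccc2c(c1)/C(=C\C(=O)OC(C)(C)C)C(=O)N2`, differs from compound 2 by methyl in place of hydrogen on an aromatic carbon, the methyl sitting on an aromatic carbon of a six-membered aromatic ring of carbon only, part of a fused system of two rings, meta to a fused ring and para to a fused ring. Going by the values given here, no measured step touches this ring. The two steps that exist, one at the ester oxygen and one at the ring nitrogen, both stayed within the scatter, so in this assay no step beyond the scatter is expected here either; compound 4 is expected at a number 1.3 percentage points lower from compound 2 to compound 4 (within the scatter). The estimate for compound 4 is 82%, with a range from 72% to 91%.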

Compound 4, percent growth inhibition at one concentration: 83.7%
Beside the measured number, compound 4's estimate is 1.7 percentage points below it; the range from low to high includes it.
By their numbers in this assay, from the lowest: compounds 1, 3, 2 and 4 (each within the scatter of the next).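

In this assay, methyl in place of hydrogen on an aromatic carbon gives a number 0.4 percentage points higher from compound 2 to compound 4 (within the scatter) and is the only step shown on the aromatic ring. It extends what the steps at the ester oxygen and the ring nitrogen showed: at this carbon, meta to a fused ring and para to a fused ring, a methyl also leaves the number within the scatter of compound 2. Nothing available explains this result or links it to any measured property.

From the compounds shown here alone, whether this carbon stays as undemanding with a different group, such as an amine, a methoxy group or a chlorine atom, remains open. Also open, going by these compounds, is whether a carboxylic acid in place of the tert-butyl ester would leave the number within the scatter.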